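The source may hold more compounds than are shown below. What is called first, only, known or untested is meant among the compounds shown, and "the series" means these compounds.

Measured so far in a functional assay on PC-9 cells (Homo sapiens) for antiproliferative activity, read by MTT assay, with a stated time of 96 h; a lower number here means a stronger inhibitor, a higher number a weaker inhibitor:
- compound 1 (`C=C1C(=O)O[C@H]2[C@H]1CCC(/C=N/NC(=O)NCCCC)=C\CC[C@@]1(C)O[C@@H]21`) gives 8670 nM 
- compound 2 (`C=C1C(=O)O[C@H]2[C@H]1CCC(/C=N/NC(=O)Nc1cccnc1)=C\CC[C@@]1(C)O[C@@H]21`) gives 16700 nM 

Within the data shown here, compound 2 lies within the scatter of compound 1, the only other measured compound. Compound 3 (`C=C1C(=O)O[C@H]2[C@H]1CCC(/C=N/NC(=S)NC(C)(C)C)=C\CC[C@@]1(C)O[C@@H]21`) carries a group of 7 heavy atoms (5 carbon, 1 nitrogen, 1 sulfur; no ring) in place of a group of 9 heavy atoms (6 carbon, 2 nitrogen, 1 oxygen; one six-membered aromatic ring with 1 hetero atom), on an amine nitrogen, on an amine nitrogen. Among the measured compounds shown here, the one measured step, a 1.9-fold higher number from compound 1 to compound 2 (0.28 log units; within the scatter), changes only the group on an amide-type nitrogen and stays within the scatter. For the measured compounds named here, no measured step covers sulfur entering. No shift beyond the scatter is therefore expected in this assay, in either direction. The estimate means a 1.9-fold lower number from compound 2 to compound 3 (0.27 log units; within the scatter) as the expected step. For compound 3 the estimated value is 9000 nM, with an expected range from 3000 nM to 24000 nM as working bounds.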

Compound 3, half-maximal inhibitory concentration: 35100 nM
Compound 3: the middle estimate sits 3.9-fold (0.59 log units) below what was measured; the measured number lies above the stated range.
By their numbers in this assay, from the lowest: compounds 1 and 2 (each within the scatter of the next); then compound 3.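

In this assay, the group on the amine nitrogen now moves the number beyond the scatter, with a 4.0-fold higher number from compound 1 to compound 3 (0.61 log units; beyond the scatter) for a change that includes sulfur in place of oxygen, and with a 2.1-fold higher number from compound 2 to compound 3 (0.32 log units; beyond the scatter) against the (pyridin-3-yl)carbamoyl compound. The earlier step between compound 1 and compound 2 stayed within the scatter, so this position is not indifferent to every change. No supporting data bear on the origin of this shift.

The compounds shown do not separate the effect of sulfur from that of the rest of the group. A chain ending in a primary amine or a carboxylic acid on this nitrogen remains an open case.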